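Benzylthio aryl swap in a dihydropyrimidine carboxanilide series

A few compounds are considered here, and "the series" means these few. Any claim that something is new, unique, unknown or untested is made for them only; others in the source may bear on it.

Two pairs of compounds share one structural change, the 2-chlorobenzyl sulfide being exchanged for its 3-chlorobenzyl counterpart, while the rest of each molecule stays fixed. The measured pair is compound 1 `CC1=C(C(=O)Nc2ccc(Br)cc2)C(c2ccc(Cl)cc2Cl)N=C(SCc2ccccc2Cl)N1` and compound 2 `CC1=C(C(=O)Nc2ccc(Br)cc2)C(c2ccc(Cl)cc2Cl)N=C(SCc2cccc(Cl)c2)N1`; in a functional assay on the whole organism (artery, strain albino) with Rattus norvegicus as the target, with a stated time of 600 min, at a dose of 10 mg/kg by the oral route (on this read-out higher numbers stand for more inhibition at the one dose given (going by the name of the read-out) and lower numbers for less inhibition), compound 1 gives 24.6% and compound 2 gives 15.4%, so the change 3-chlorophenyl in place of 2-chlorophenyl on a saturated chain carbon bound to a sulfur yields a number 9.2 percentage points lower from compound 1 to compound 2 (within the scatter). The third measured member, compound 3 `CC1=C(C(=O)Nc2ccc([N+](=O)[O-])cc2)C(c2ccc(Br)cc2)N=C(SCc2ccccc2Cl)N1`, is built on a different core: the difference between the core of compound 1 and the core of compound 3 is not broken down here. In this assay compound 3 gives 9.7%, the lowest of the three numbers, within the scatter of compound 2 and beyond it only against compound 1.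

Compound 4 `CC1=C(C(=O)Nc2ccc([N+](=O)[O-])cc2)C(c2ccc(Br)cc2)N=C(SCc2cccc(Cl)c2)N1` carries the same change on the core of compound 3, described by 3-chlorophenyl in place of 2-chlorophenyl on a saturated chain carbon bound to a sulfur. The place is the same in both pairs, so the change is the same, not merely the same kind. For the measured compounds named here, for compound 4 the step is expected to read a number 6.7 percentage points lower from compound 3 to compound 4 (within the scatter), resting on the single precedent, because a number 9.2 percentage points lower from compound 1 to compound 2 (within the scatter) was small and within the scatter; with only one prior instance the expectation is loose. Compound 4 is therefore estimated at 3%, with a plausible span from -9% to 15%.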

Compound 4, a percentage reported as inhibition, in the whole organism at one dose (the size of the read-out at that dose, not a potency): 5.1%
For compound 4 the middle estimate is 2.1 percentage points below the measured one, within the range that was stated.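

In this assay, exchanging 2-chlorobenzyl for 3-chlorobenzyl on the core of compound 3 gives a number 4.6 percentage points lower from compound 3 to compound 4 (within the scatter). Set beside the same exchange on the core of compound 1, the step shows no measurable dependence on the core: the same change on two cores in this assay, a number 9.2 percentage points lower (within the scatter) from compound 1 to compound 2 and a number 4.6 percentage points lower (within the scatter) from compound 3 to compound 4, 4.6 percentage points apart, within the scatter of two such steps Neither step lies beyond the scatter, so the pairs do not establish that the exchange has a real effect on either core, and agreement between two noise-sized steps says little about how it would behave on a third core or in a series with higher numbers.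

The two cores differ in more than one place, so the compounds shown do not separate the contribution of the anilide substituent from that of the aryl group on the ring, and they cannot show whether either part alters the result of the exchange. Also open, as far as these compounds go, is whether a larger step would appear with a different group on the sulfur, such as an unsubstituted benzyl, a longer chain ending in a phenyl ring, or a benzyl carrying a carboxylic acid or an amine.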